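Propyl to tert-butyl on the amide nitrogen

The source may hold more compounds than are shown below. What is called first, only, known or untested is meant among the compounds shown, and "the series" means these compounds.

Compound 1 `C=CC1=C(C(=O)NCCC)C(c2ccc(Cl)c(Cl)c2)OC1` has been tested in a functional assay on HeLa cells (Homo sapiens) for cytotoxicity, read by MTT assay, with a stated time of 24 h; a higher number here means a weaker inhibitor, a lower number a stronger inhibitor. In this assay compound 1 reaches only a limit, > 100000 nM. Compound 2 `C=CC1=C(C(=O)Nc2ccc(OCC)cc2)C(c2ccc(F)cc2)OC1` likewise returns a limit in this assay, > 100000 nM. Compound 3 `C=CC1=C(C(=O)O)C(c2ccc(OC)c(OC)c2)OC1` gives a number in this assay, 18000 nM. Among the measured compounds shown here, compound 1 therefore stands at the limit of > 100000 nM in this assay, at which 2 of the 3 values shown sit, and no step between two measured compounds has been worked out. Compound 4 `C=CC1=C(C(=O)NC(C)(C)C)C(c2ccc(Cl)c(Cl)c2)OC1` differs from compound 1 in a single place: tert-butyl in place of propyl on an amide-type nitrogen. With compound 1 sitting at the limit, no step beyond the usual scatter is expected, and the result for compound 4 is expected to be another limit rather than a number. For compound 4 the estimate is 100000 nM, within 40000 nM to 300000 nM, meaning an expected step of a number no higher from compound 1 to compound 4 (the limit leaves the size open).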

Compound 4, half-maximal inhibitory concentration: > 100000 nM
Compound 4 gave a limit, no number; the forecaster's own chance of this, stated with the estimate: 80%; the middle value lies on the limit itself.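

Among the compounds shown here, compound 1 and compound 4 both return only a limit, so no step between them can be read. The compounds shown leave open whether tert-butyl and propyl on the amide-type nitrogen differ at all in this assay.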